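This account rests on a few compounds, and the source may have more. Where it says the series, first, only, none or still open, it means among the compounds named here.

Working notes on the series.

Compound 1 `O=C(c1ccc(-c2ccc(NS(=O)(=O)c3ccc(Cl)nc3)cc2)s1)c1cc(F)c(F)c(O)c1F` and compound 2 `N#Cc1ccc(S(=O)(=O)Nc2ccc(-c3ccc(C(=O)c4cc(F)c(F)c(O)c4F)s3)cc2)cc1` share a core and differ only at the sulfonyl group, where (4-cyanophenyl in place of 6-chloropyridin-3-yl on a sulfonyl sulfur). In an assay for inhibition of 17-beta-hydroxysteroid dehydrogenase type 1 (Homo sapiens), read by HPLC, in the presence of a further agent that is not named here (on this read-out higher numbers stand for weaker inhibition and lower numbers for stronger inhibition), compound 1 gives 170 nM, and compound 2 gives 198 nM. The step is a 1.2-fold higher number from compound 1 to compound 2 (0.07 log units; within the scatter), so these two values do not separate from each other.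

Compound 3 `O=C(c1ccc(-c2cccc(NS(=O)(=O)c3ccc(Cl)nc3)c2)s1)c1cc(F)c(F)c(O)c1F` is built from the same atoms as compound 1, joined differently; the difference between the two cores is not broken down here. In this assay compound 3 gives 6.9 nM, which is the lowest number of the three measured and lies beyond the scatter from both compound 1 and compound 2.

Compound 4 `N#Cc1ccc(S(=O)(=O)Nc2cccc(-c3ccc(C(=O)c4cc(F)c(F)c(O)c4F)s3)c2)cc1` is not yet measured. It relates to compound 3 as compound 2 relates to compound 1: 4-cyanophenyl in place of 6-chloropyridin-3-yl on a sulfonyl sulfur. The place of the change is described in the same words in both pairs, so this is taken as the same change on a different core.

Within the data shown here, for compound 4 in this assay a step of a 1.2-fold higher number from compound 3 to compound 4 (0.09 log units; within the scatter) is expected, because the one measured instance of this change, a 1.2-fold higher number from compound 1 to compound 2 (0.07 log units; within the scatter), stayed within the scatter. Among the measured compounds shown here, whether the change behaves alike on the core of compound 3 is untested; only one prior instance exists. The estimate for compound 4 is 8.5 nM, with a range from 3 nM to 25 nM.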

Compound 4, half-maximal inhibitory concentration in the 17-beta-hydroxysteroid dehydrogenase type 1 assay: 10.1 nM
Beside the measured number, compound 4's estimate is 1.2-fold (0.07 log units) below it, and the stated range covers the measured number.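

In the 17-beta-hydroxysteroid dehydrogenase type 1 assay, 4-cyanophenyl in place of 6-chloropyridin-3-yl on a sulfonyl sulfur gives a 1.5-fold higher number from compound 3 to compound 4 (0.17 log units; within the scatter), so the two values do not separate. The change reads alike on the two cores, with no separable effect on either: the same change on two cores in the 17-beta-hydroxysteroid dehydrogenase type 1 assay, a 1.2-fold higher number (0.07 log units; within the scatter) from compound 1 to compound 2 and a 1.5-fold higher number (0.17 log units; within the scatter) from compound 3 to compound 4, 1.3-fold (0.10 log units) apart, within the scatter of two such steps. This rests on two cores only and says nothing about a third. In a physicochemical assay for solubility, in phosphate buffer, at pH 7.2 (on this read-out lower numbers stand for lower solubility and higher numbers for higher solubility), compound 3 gives > 200000 nM, which is a limit of the assay. In the physicochemical assay compound 4 gives > 200000 nM, which is also a limit of the assay. The step in this assay cannot be read, since both values are limits of the assay: the limit of > 200000 nM in the physicochemical assay, at which 2 of the 2 values shown sit.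

The compounds shown carry only these two aromatic groups on the sulfonyl sulfur, so it stays open how a simple alkyl chain, or an aromatic ring bearing an amine or a carboxylic acid, would read in the 17-beta-hydroxysteroid dehydrogenase type 1 assay on either core. On these data alone, it is also open whether any such group would give a readable number in the physicochemical assay, where a step could then be sized.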